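The source may hold more compounds than are shown below. What is called first, only, known or untested is meant among the compounds shown, and "the series" means these compounds.

Working notes on the antiproliferative series. For the measured compounds named here, compound 2 `CCOC(=O)/C=N/c1cnc(Nc2ccc(S(N)(=O)=O)cc2)nc1NC1CCCC1` is the one member with a numerical read-out: in a functional assay on HeLa cells (Homo sapiens) for antiproliferative activity, read by MTT assay (on this read-out lower numbers stand for stronger inhibition and higher numbers for weaker inhibition), compound 2 gives 20700 nM. Compound 1 `CN1CCN(c2ccc(Nc3ncc(/N=C/c4ccc(C(F)(F)F)cc4)c(NC4CCCC4)n3)cc2)CC1` in this assay gives > 100000 nM, which is a limit of the assay and not a number; the evidence here is the limit of > 100000 nM in this assay, at which 1 of the 2 values shown sits. Going by the values given here, no step between two measured compounds can be drawn from these two.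

The next compound, compound 3 `NS(=O)(=O)c1ccc(Nc2ncc(/N=C/c3ccc(C(F)(F)F)cc3)c(NC3CCCC3)n2)cc1`, keeps the sulfonamide aniline side of compound 2 and differs from it as follows: 4-(trifluoromethyl)phenyl in place of ethoxycarbonyl on a carbon with a double bond to nitrogen. Compound 1 carries the same 4-(trifluoromethyl)phenyl group on that carbon and sits at the limit in this assay. For the step of a 2.9-fold higher number from compound 2 to compound 3 (0.46 log units; beyond the scatter) a loss of potency beyond the usual scatter is expected, with a real chance that only a limit is reported. Compound 3 is therefore expected to come out near 60000 nM, within a range of 15000 nM to 200000 nM.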

Compound 3, half-maximal inhibitory concentration: 21900 nM
Compound 3: the middle estimate sits 2.7-fold (0.44 log units) above what was measured; the range from low to high includes it.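

In this assay the carbon with a double bond to nitrogen accepts 4-(trifluoromethyl)phenyl in place of ethoxycarbonyl with the read-out staying within the scatter, as a 1.1-fold higher number from compound 2 to compound 3 (0.02 log units; within the scatter) shows, so on the sulfonamide aniline side these two groups cannot be told apart. The other exchange, sulfamoyl in place of 4-methylpiperazin-1-yl on an aromatic carbon, gives an at least 4.5-fold lower number from compound 1 to compound 3 (0.65 log units; beyond the scatter), which shows that 4-(trifluoromethyl)phenyl on that carbon does not by itself put a compound at the limit. That step is bounded on one side only, since compound 1 stands at a limit of the assay and not at a number: the limit of > 100000 nM in this assay, at which 1 of the 3 values shown sits.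

From the compounds shown here alone, whether the read-out holds with a carboxylic acid or a plain methyl on that carbon stays open. Also open, going by these compounds, is how ethoxycarbonyl behaves alongside 4-methylpiperazin-1-yl.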